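Swapping the Aryl Group on Compound 3

This account rests on a few compounds, and the source may have more. Where it says the series, first, only, none or still open, it means among the compounds named here.

- compound 1 `CC[C@H]1c2c(cc(F)c(F)c2O)[C@H](Nc2cccc3[nH]c(=O)ccc23)[C@@](O)(C(F)(F)F)C1OC`: 6.31 nM
- compound 2 `CCSC[C@@](O)([C@@H](Nc1cccc2nc(C)ccc12)c1ccc(OC)cc1)C(F)(F)F`: 6.31 nM
- compound 3 `CCSC[C@@](O)([C@@H](Nc1cccc2nc(C)ccc12)c1ccc(F)cc1OC)C(F)(F)F`: 5.01 nM

In a functional assay on THP-1 cells (Homo sapiens) (on this read-out lower numbers stand for stronger inhibition and higher numbers for weaker inhibition), compound 3 gives 5.01 nM, which lies within the scatter of the values for compound 1 and compound 2. Compound 4 `CCSC[C@@](O)([C@@H](Nc1cccc2nc(C)ccc12)c1ccc(Cl)c(F)c1O)C(F)(F)F` is not yet measured. It carries 4-chloro-3-fluoro-2-hydroxyphenyl in place of 4-fluoro-2-methoxyphenyl, on a saturated chain carbon bound to a nitrogen on an aromatic ring and a saturated chain carbon: 4-chloro-3-fluoro-2-hydroxyphenyl in place of 4-fluoro-2-methoxyphenyl on a saturated chain carbon bound to a nitrogen on an aromatic ring and a saturated chain carbon.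

One measured step changes the group at this place: a 1.3-fold lower number from compound 2 to compound 3 (0.10 log units; within the scatter). That step stays within the scatter, so it offers only modest guidance. For the measured compounds named here, no measured step swaps a methoxy group for a hydroxy group or brings in a chlorine, so the data cannot settle this change directly. Compound 1 has a different core but also carries a hydroxy group on a fluorinated ring, and its value is 6.31 nM. No change beyond the scatter is therefore expected in this assay, and no direction can be firmly expected. The estimated step is a 1.3-fold lower number from compound 3 to compound 4 (0.10 log units; within the scatter). The expected value for compound 4 is 4 nM, with an estimated range of 1.3 nM to 12.6 nM.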

Compound 4, half-maximal inhibitory concentration: 20 nM
Compound 4: the middle estimate sits 5.0-fold (0.70 log units) below what was measured; the measured number lies above the stated range.
By their numbers in this assay, from the lowest: compounds 3, 1 and 2 (each within the scatter of the next); then compound 4.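

Unlike the earlier step at this place, which stayed within the scatter, the 4-chloro-3-fluoro-2-hydroxyphenyl group moves the result beyond it: this assay shows a 4.0-fold higher number from compound 3 to compound 4 (0.60 log units; beyond the scatter), and also a 3.2-fold higher number from compound 2 to compound 4 (0.50 log units; beyond the scatter). Inhibition at this place therefore does respond to the choice of aromatic group, and this particular group weakens it. The swap brings in a hydroxy group and a chlorine together, and no measurement shown explains the weaker inhibition.

The compounds shown leave open whether the hydroxy group, the chlorine or the combination accounts for the shift. A 4-chloro-2-methoxyphenyl group and a 4-fluoro-2-hydroxyphenyl group would each separate these changes, while an amine in place of the hydroxy group would test another replacement at the same ring.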